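Dichlorophenyl swap in the series: compound 2 to compound 3

This account rests on a few compounds, and the source may have more. Where it says the series, first, only, none or still open, it means among the compounds named here.

Compound 1 `CNC(=O)c1cc(Oc2ccc(C(=O)/C=C/c3ccccc3)cc2)ccn1` – 3170 nM
Compound 2 `CNC(=O)c1cc(Oc2ccc(C(=O)/C=C/c3ccc(Cl)cc3Cl)cc2)ccn1` – 9220 nM

Within the data shown here, in a functional assay on PC-3 cells (Homo sapiens) for cytotoxicity, read by MTT assay, with a stated time of 72 h (a lower number here means a stronger inhibitor, a higher number a weaker inhibitor), compound 2 holds the higher of the two numbers, 9220 nM, and its only neighbour is compound 1 at 3170 nM. The next compound to be tested is compound 3 `CNC(=O)c1cc(Oc2ccc(C(=O)/C=C/c3cccc(Cl)c3Cl)cc2)ccn1`. The change is 2,3-dichlorophenyl in place of 2,4-dichlorophenyl on a double-bonded chain carbon bound to a double-bonded chain carbon.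

Among the measured compounds shown here, one measured step bears on this, a 2.9-fold higher number from compound 1 to compound 2 (0.46 log units; beyond the scatter), a modest step beyond the scatter that came with 2,4-dichlorophenyl in place of phenyl. For the measured compounds named here, it does not cover the present change, since no measured pair shares the same atoms joined differently. It gives only a rough scale, and it offers no firm direction. In this assay a step no larger than the scatter is therefore the main expectation, with a slight lean towards a lower number. The expected step is a 1.4-fold lower number from compound 2 to compound 3 (0.15 log units; within the scatter). For compound 3 the estimated value is 6500 nM, with an expected range from 2800 nM to 14000 nM.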

Compound 3, half-maximal inhibitory concentration: > 50000 nM
Compound 3 ended at the assay's limit (the forecaster's own chance of this, stated with the estimate: 5%); at least 7.6-fold (0.88 log units) between middle value and limit.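

In this assay, 2,3-dichlorophenyl in place of 2,4-dichlorophenyl, with the same atoms joined differently, comes with an at least 5.4-fold higher number from compound 2 to compound 3 (0.73 log units; beyond the scatter), so at this place the arrangement of the two chlorines matters and not only their presence. Set against phenyl, 2,3-dichlorophenyl gives an at least 15-fold higher number from compound 1 to compound 3 (1.19 log units; beyond the scatter), a large step, where 2,4-dichlorophenyl gave the modest 2.9-fold higher number from compound 1 to compound 2 (0.46 log units; beyond the scatter), and so both dichlorophenyl groups go the same way from phenyl but to clearly different extents. The entry for compound 3 is a limit of the assay and not a number, and it is the only such entry among the compounds so far: the limit of > 50000 nM in this assay, at which 1 of the 3 values shown sits.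

Still open, from the compounds shown here alone, is whether the higher numbers belong to chlorine as such or to these particular dichloro patterns, which a chlorophenyl, methoxyphenyl or aminophenyl group at this place would help to separate. Also open, going by these compounds, is whether any group on this double-bonded chain carbon gives a lower number than compound 1 at 3170 nM.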